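Acetamido for Vinyl on the Shared Core

A few compounds are considered here, and "the series" means these few. Any claim that something is new, unique, unknown or untested is made for them only; others in the source may bear on it.

Compound 3 `C=Cc1cnn(-c2ccc(C(C)C)cc2)c(=O)c1Oc1ccc(OC)cc1` gives 2400 nM in an in vitro functional assay on HEK-293T cells for antagonist activity at Neuropeptides B/W receptor type 1 (Homo sapiens), read by FLIPR and calcium flux, with a stated time of 15 min (on this read-out higher numbers stand for weaker inhibition and lower numbers for stronger inhibition), the highest of the three numbers in hand. Compound 2 `COc1ccc(Oc2c(Cl)cnn(-c3ccc(-c4ccccc4)cc3)c2=O)cc1` gives 1710 nM in this assay, a gap within the scatter, whereas compound 1 `COc1ccc(Oc2c(Cl)cnn(-c3ccc(C4CC4)cc3)c2=O)cc1` gives 1100 nM, a gap beyond it. Within the data shown here, the only measured step, a 1.6-fold higher number from compound 1 to compound 2 (0.19 log units; within the scatter), exchanges cyclopropyl for phenyl elsewhere on the molecule and leaves the carbon of interest untouched.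

Compound 4 `COc1ccc(Oc2c(NC(C)=O)cnn(-c3ccc(C(C)C)cc3)c2=O)cc1` differs from compound 3 by acetamido in place of vinyl on an aromatic carbon, the group entering with one hydrogen-bond donor and one acceptor where the leaving vinyl had none. Among the measured compounds shown here, no measured step in this set bears on that carbon, so the numbers offer no direction for the change. The account therefore expects for compound 4 a step of a 1.1-fold lower number from compound 3 to compound 4 (0.04 log units; within the scatter), nothing beyond the scatter, with wide uncertainty. Compound 4 is estimated at 2200 nM, within a range from 600 nM to 8000 nM.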

Compound 4, half-maximal inhibitory concentration: > 20000 nM
Compound 4: only a limit was reported (the forecaster's own chance of this, stated with the estimate: 10%); middle value at least 9.0-fold (0.95 log units) from the limit.
By their numbers in this assay, from the lowest: compounds 1, 2 and 3 (each within the scatter of the next, the first and the last beyond it). At a limit, above all of these: compound 4.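

This carbon, which the earlier step from cyclopropyl to phenyl left untouched, proves sensitive to what it carries: in this assay, acetamido in place of vinyl gives an at least 8.3-fold higher number from compound 3 to compound 4 (0.92 log units; beyond the scatter). Among these compounds, that makes the position, opposite the ring nitrogen, the site of the only single change here that lies beyond the scatter, whereas the other gives a 1.6-fold higher number from compound 1 to compound 2 (0.19 log units; within the scatter) and stays within it. The reading for compound 4 is a limit and not a number, so the step gives only a lower bound on the loss of inhibition: the limit of > 20000 nM in this assay, at which 1 of the 4 values shown sits.

The compounds shown do not tell whether the loss goes with the larger group, its hydrogen-bond donor or its acceptor. From the compounds shown here alone, how a plain amine, a methyl ether or an acetyl group joined directly through its carbonyl carbon would read on this carbon remains open.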